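The source may hold more compounds than are shown below. What is called first, only, known or untested is meant among the compounds shown, and "the series" means these compounds.

Measured so far in an ADME assay on Raji cells (Homo sapiens) for inhibition, with a stated time of 72 h; a lower number here means that less compound is needed, a higher number that more compound is needed for the effect:
compound 1 `C/C=C/C(=O)Nc1cccc(-c2nc3ccccc3s2)c1` gives > 25000 nM, a limit of this assay.
compound 2 `O=C(O)/C=C/C(=O)Nc1cccc(-c2nc3ccccc3s2)c1` gives > 25000 nM, a limit.
compound 3 `CC(C)(CCl)C(=O)Nc1cccc(-c2nc3ccccc3s2)c1` gives > 25000 nM, a limit.

Compound 1 therefore stands only at a limit in this assay, and the three values sit together at the limit of > 25000 nM in this assay, at which 3 of the 3 values shown sit. The steps a step that the two limits leave unreadable from compound 1 to compound 2, a step that the two limits leave unreadable from compound 1 to compound 3 and a step that the two limits leave unreadable from compound 2 to compound 3 are of unreadable size for that reason. Compound 4 `O=C(Nc1cccc(-c2nc3ccccc3s2)c1)c1cccnc1Cl`, not yet measured, differs from compound 1 by 2-chloropyridin-3-yl in place of prop-1-en-1-yl on a carbonyl carbon. Among the measured compounds shown here, no measured step has a readable size that bears on this change, so neither a direction nor a size can be drawn from them. Compound 4 is estimated at 15000 nM with a range of 2000 nM to 50000 nM in this assay. The expected step of an at least 1.6-fold lower number from compound 1 to compound 4 (0.22 log units; that floor lies within the scatter) is thus an estimate without support from a readable measured step.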

Compound 4, half-maximal effective concentration: > 25000 nM
Compound 4: only a limit was reported; the forecaster's own chance of this, stated with the estimate: 55%; middle value at least 1.6-fold (0.22 log units) away from the limit.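

Compound 4 also stands only at a limit, so its steps from compound 1, compound 2 and compound 3 cannot be read: the limit of > 25000 nM in this assay, at which 4 of the 4 values shown sit.

The compounds shown leave open whether any group on the carbonyl carbon of the shared core gives a measurable value.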